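Swapping the Trifluoromethylphenyl Amide Arm for a Phenylethenyl Arm

The compounds below may be only part of what the source reports. "The series", "measured", "known", "first", "only" and "open" are said of these compounds alone.

Two measured compounds share one core and differ in a single group. Compound 1 `Cc1ccc(C(=O)N2N=C(c3ccc(N4CCN(C)CC4)cc3)CC2c2ccc(N(C)C)cc2)cc1` carries a methyl on an aromatic carbon, and in a functional assay on NCI-H1975 cells (Homo sapiens) for inhibition, read by sulforhodamine B assay, tested at 10 uM (a higher number here means more inhibition at the concentration tested (going by the name of the read-out), a lower number less inhibition), compound 1 gives -0.4%. Compound 2 `CN1CCN(c2ccc(C3=NN(C(=O)c4ccc(C(F)(F)F)cc4)C(c4ccc(N(C)C)cc4)C3)cc2)CC1` carries a trifluoromethyl in that place, and in this assay compound 2 gives 93.2%. Within the data shown here, the one measured step, a number 93.6 percentage points higher from compound 1 to compound 2 (beyond the scatter), leaves compound 2 as the higher of the two values shown, beyond the scatter above compound 1.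

Compound 3 `CN1CCN(c2ccc(C3=NN(C(=O)/C=C/c4ccccc4)C(c4ccc(N(C)C)cc4)C3)cc2)CC1` alters compound 2 at a different spot: 2-phenylethenyl in place of 4-(trifluoromethyl)phenyl on a carbonyl carbon. Among the measured compounds shown here, no measured step touches the group on the carbonyl carbon, so nothing directly tells how this change will read. For the measured compounds named here, the only guidance is that, because of the size of a number 93.6 percentage points higher from compound 1 to compound 2 (beyond the scatter), the arm attached to that carbonyl can move the read-out across almost its whole range, so a step of any size in either direction is possible. Compound 3 is expected to fall near 45%, somewhere between 0% and 95%. This estimate amounts to an expected step of a number 48.2 percentage points lower from compound 2 to compound 3 (beyond the scatter).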

Compound 3, a percentage reported as inhibition, at one concentration (the size of the read-out at that concentration, not a potency): 81%
Beside the measured number, compound 3's estimate is 36 percentage points below it; the measured number falls inside the stated range.
By their numbers in this assay, from the lowest: compound 1; then compound 3; then compound 2.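

In this assay, the arm on the carbonyl carbon can change a good deal and still give a high reading: when 2-phenylethenyl replaces 4-(trifluoromethyl)phenyl, the step (a number 12.2 percentage points lower from compound 2 to compound 3 (beyond the scatter)) is modest, even though the new arm has a double bond outside aromatic rings and no fluorine. The earlier pair could have suggested that a high reading depends on the trifluoromethyl group, but the large step (a number 81.4 percentage points higher from compound 1 to compound 3 (beyond the scatter)) shows that an arm without it can also lift the reading far above that of the 4-methylphenyl arm, so the pattern does not hold for every arm lacking trifluoromethyl. Nothing available explains why these three arms read as they do.

A saturated 2-phenylethyl arm on the carbonyl carbon would test whether the double bond matters to the reading of compound 3, while a 4-chlorophenyl or 4-cyanophenyl arm would show whether other groups on the benzene ring can match trifluoromethyl. On these data alone, these readings come from one concentration, so how compound 2 and compound 3 compare in potency also remains open.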